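This account rests on a few compounds, and the source may have more. Where it says the series, first, only, none or still open, it means among the compounds named here.

In an ADME assay on HepG2 cells (Homo sapiens) for cytotoxicity (a lower number here means that less compound is needed, a higher number that more compound is needed for the effect), compound 1 `Cc1ccc(S(=O)(=O)N[C@@H](CC(=O)NC(C)(C)C)C(=O)NCCNC(=O)c2c(O)cccc2F)cc1` gives > 11000 nM, which is a limit of the assay and not a number. Compound 2 `COc1cccc(C(=O)NCCNC(=O)[C@H](CC(=O)NC(C)(C)C)NS(=O)(=O)c2ccc(C)cc2)c1` gives > 11000 nM, which is also only a limit. The picture so far is therefore (the limit of > 11000 nM in this assay, at which 2 of the 2 values shown sit). Compound 3 `Cc1ccc(S(=O)(=O)N[C@@H](CC(=O)NC(C)(C)C)C(=O)NCCNC(=O)c2ccccc2Cl)cc1` keeps the core of compound 2 and places 2-chlorophenyl in place of 3-methoxyphenyl on a carbonyl carbon. Within the data shown here, the one measured change at this place, 3-methoxyphenyl in place of 2-fluoro-6-hydroxyphenyl, is a step that the two limits leave unreadable from compound 1 to compound 2. That step offers no size to carry over to the new change, so no step beyond the scatter is expected in this assay. The expected step is a step that the limit leaves unreadable from compound 2 to compound 3. Compound 3 is expected to come out at 15000 nM, with an estimated range from 11000 nM to 40000 nM, and quite possibly as a limit again.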

Compound 3, half-maximal effective concentration: > 11000 nM
Compound 3 ended at the assay's limit; the forecaster's own chance of this, stated with the estimate: 90%; the middle value lies beyond the limit too.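

Compound 1, compound 2 and compound 3 all end at a limit and not at a number, so no step among them can be read in this assay: the limit of > 11000 nM in this assay, at which 3 of the 3 values shown sit.

The compounds shown leave open how much of any of the three is needed for the effect, and whether changing the group on the carbonyl carbon shifts that amount at all.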